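The compounds below may be only part of what the source reports. "The series", "measured", "known", "first", "only" and "open" are said of these compounds alone.

Measured in a functional assay on cells (Breast cancer cell line, Homo sapiens) for inhibition; on this read-out lower numbers stand for stronger inhibition of growth and higher numbers for weaker inhibition of growth:
- compound 1 `Cc1ccc(/C=C2\CN(C)CC3=C2N=C(S)NC3c2ccc(C)cc2)cc1`: 88800 nM
- compound 2 `CN1C/C(=C\c2cccs2)C2=NN(C)C(c3cccs3)C2C1`: > 100000 nM

Compound 2 has no exact number, and its > 100000 nM is only a limit of this assay. Going by the values given here, this limit applies to one of the two compounds measured so far, (the limit of > 100000 nM in this assay, at which 1 of the 2 values shown sits).

Compound 3 `CN1C/C(=C\c2cccs2)C2=NN(c3ccccc3)C(c3cccs3)C2C1` differs from compound 2 in one place. It has phenyl in place of methyl on an amine nitrogen in a ring, which is next to the ring atom that bears a thiophen-2-yl group (phenyl in place of methyl on an amine nitrogen in a ring).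

Among the compounds with values here, no measured pair shows what this swap does, so only a modest shift towards stronger inhibition of growth is expected, and it may not exceed the usual scatter. The expected size of the change is the estimated at least 1.4-fold lower number from compound 2 to compound 3 (0.15 log units; that floor lies within the scatter). For compound 3 the expected value is 70000 nM, with an estimated range of 25000 nM to 100000 nM.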

Compound 3, concentration for total growth inhibition: > 100000 nM
Compound 3 ended at the assay's limit; the forecaster's own chance of this, stated with the estimate: 45%; at least 1.4-fold (0.15 log units) between middle value and limit.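

Compound 2 and compound 3 both sit at a limit of this assay rather than at an exact number, so no step between them can be read: the limit of > 100000 nM in this assay, at which 2 of the 3 values shown sit.

On these data alone, whether phenyl in place of methyl changes growth inhibition at all, and in which direction, stays open.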